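Dropping the Ring Methyl from the Piperidine Chain

A few compounds are considered here, and "the series" means these few. Any claim that something is new, unique, unknown or untested is made for them only; others in the source may bear on it.

Measured compounds:
compound 1, `COc1cc2c(Nc3nc4ccc(C(=O)Nc5c(C)cccc5Cl)cc4s3)ncnc2cc1OCCCN1CCCCC1C`: 5300 nM
compound 2, `COc1cc2c(Nc3nc4ccc(C(=O)Nc5c(C)cccc5C)cc4s3)ncnc2cc1OCCCN1CCCCC1C`: 84400 nM

In a functional assay on NCI-H661 cells (Homo sapiens) for cytotoxicity, read by WST assay, with a stated time of 72 h (a lower number here means a stronger inhibitor, a higher number a weaker inhibitor), compound 1 gives 5300 nM, the lowest of the two numbers; the nearest is compound 2, which gives 84400 nM. Going by the values given here, the one measured step, a 16-fold higher number from compound 1 to compound 2 (1.20 log units; beyond the scatter), concerns the aryl amide, not the side chain. Compound 3, `COc1cc2c(Nc3nc4ccc(C(=O)Nc5c(C)cccc5Cl)cc4s3)ncnc2cc1OCCCN1CCCCC1`, differs from compound 1 by hydrogen in place of methyl on a saturated ring carbon, reading 2-methylpiperidin-1-yl to piperidin-1-yl. Among the compounds with values here, no measured step bears on this change, so compound 3 is expected to show no step beyond the scatter, a 1.1-fold lower number from compound 1 to compound 3 (0.03 log units; within the scatter). Compound 3 is estimated at 5000 nM, within 1500 nM to 16000 nM.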

Compound 3, half-maximal inhibitory concentration: 13800 nM
For compound 3 the middle estimate is 2.8-fold (0.44 log units) below the measured one, within the range that was stated.
By their numbers in this assay, from the lowest: compound 1; then compound 3; then compound 2.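

In this assay, the change from 2-methylpiperidin-1-yl to piperidin-1-yl gives a 2.6-fold higher number from compound 1 to compound 3 (0.42 log units; beyond the scatter), so this methyl on the saturated ring carbon affects the reading, which the aryl amide step alone could not show. That modest step is smaller than a 16-fold higher number from compound 1 to compound 2 (1.20 log units; beyond the scatter), so of the two changes the amide one moves the number more. Nothing here explains why the methyl has this effect.

From the compounds shown here alone, whether an ethyl group on the same ring carbon or a morpholine in place of the piperidine would match compound 1 remains open. So does whether removing the methyl has the same effect with the amide of compound 2.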